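Acyl chain to benzylamino at the carbonyl

This account rests on a few compounds, and the source may have more. Where it says the series, first, only, none or still open, it means among the compounds named here.

Compound 1 `CC(C)C(=O)NC(C(=O)N1CCC(c2ccc(Cl)cc2)CC1)C(C)C` and compound 2 `CC(C)CCC(=O)N[C@@H](C(=O)N1CCC(c2ccc(Cl)cc2)CC1)C(C)C` share the same core and differ in the acyl chain and in the drawn stereochemistry. In an assay on THP-1 cells for displacement of a labelled ligand from C-C chemokine receptor type 1 (Homo sapiens) (a higher number here means a weaker inhibitor, a lower number a stronger inhibitor), compound 1 gives 388 nM, while compound 2 gives 26 nM. Compound 2 thus holds the lowest number of the two, with compound 1 standing well above it, beyond the scatter. Compound 3 `CC(C)[C@@H](NC(=O)NCc1ccccc1)C(=O)N1CCC(c2ccc(Cl)cc2)CC1` is the next member: benzylamino in place of isopentyl on a carbonyl carbon. Within the data shown here, no measured pair shows this kind of change, so its size cannot be read from any measured step. The expectation is a modest upward step a 2.3-fold higher number from compound 2 to compound 3 (0.36 log units; beyond the scatter), possibly within the scatter, because compound 2 at 26 nM already sits low and the change replaces the isopentyl chain with a group carrying one hydrogen-bond donor. For compound 3 the estimate in this assay is 60 nM, within 15 nM to 250 nM.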

Compound 3, half-maximal inhibitory concentration: 180 nM
Compound 3: middle estimate off by 3.0-fold (0.48 log units), on the low side; the range from low to high includes it.
By their numbers in this assay, from the lowest: compound 2; then compound 3; then compound 1.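

In this assay, among these compounds, the change of isopentyl to benzylamino on a carbonyl carbon whose other neighbour is an amide-type nitrogen gives a 6.9-fold higher number from compound 2 to compound 3 (0.84 log units; beyond the scatter), the first step that can be read at a single place. This position therefore does respond to the change: the entering group, with its six-membered aromatic ring and hydrogen-bond donor, gives a higher number than the open isopentyl chain. No measurement here bears on the reason for this step.

The change adds the ring and the nitrogen together. The measured compounds do not show either one alone. Isopentylamino would keep the nitrogen without the ring and phenethyl would keep the ring without the nitrogen, so these two groups would separate the contributions.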